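The source may report more compounds than this note shows. Statements on the series, on what has been measured and on what is new or still open speak of the compounds shown alone.

Compound 1 `Cc1nc(C(F)(F)F)ccc1C(=O)Nc1ccc(Cl)c(-c2nc3ccccc3s2)c1`: 70 nM
Compound 2 `Cc1nc(C(F)(F)F)ccc1C(=O)Nc1ccc(Cl)c(-n2cccn2)c1`: 450 nM

In an assay on C3H 10T1/2 cells for inhibition of Sonic hedgehog protein (Mus musculus), read by a luciferase reporter (on this read-out higher numbers stand for weaker inhibition and lower numbers for stronger inhibition), compound 2 gives the higher of the two numbers. Within the data shown here, the only measured step, a 6.4-fold higher number from compound 1 to compound 2 (0.81 log units; beyond the scatter), swapped one aromatic group on the same aromatic carbon of the shared core. Compound 3 `Cc1nc(C(F)(F)F)ccc1C(=O)Nc1ccc(Cl)c(-c2cnccn2)c1` is not yet measured; it differs from compound 2 by pyrazin-2-yl in place of 1H-pyrazol-1-yl on an aromatic carbon. That measured step bears on this change only loosely; the group entering here is again a different one, so a step smaller than that one is expected, in either direction, possibly none beyond the scatter. Compound 3 is estimated at 300 nM, within 100 nM to 1000 nM, which means a 1.5-fold lower number from compound 2 to compound 3 (0.18 log units; within the scatter).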

Compound 3, half-maximal inhibitory concentration: 1700 nM
Compound 3: the middle estimate sits 5.7-fold (0.75 log units) below what was measured, outside the stated range (above it).
By their numbers in this assay, from the lowest: compound 1; then compound 2; then compound 3.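

Swapping one diazole-type ring for another is not neutral at this position, on an aromatic carbon ortho to a chloro group: a 3.8-fold higher number from compound 2 to compound 3 (0.58 log units; beyond the scatter) comes with pyrazin-2-yl, although the hydrogen-bond donor and acceptor counts stay the same as for 1H-pyrazol-1-yl. Against 1,3-benzothiazol-2-yl the loss is wider, with a 24-fold higher number from compound 1 to compound 3 (1.39 log units; beyond the scatter) as the largest step so far, so among these three groups pyrazin-2-yl gives the weakest inhibition. The data offer no measured reason for this order. From the compounds shown here alone, how a plain phenyl ring or a small amine on this carbon would compare remains open.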